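Cyano to bromo on the aryl ring of compound 2

The compounds below may be only part of what the source reports. "The series", "measured", "known", "first", "only" and "open" are said of these compounds alone.

In a functional assay on A549 cells (Homo sapiens) for inhibition, read by MTT assay, with a stated time of 24 h (a higher number here means a weaker inhibitor, a lower number a stronger inhibitor), compound 2 `CCOC(=O)c1c(C)[nH]c(=O)c(C#N)c1-c1ccc(C#N)cc1` reaches only the limit > 100000 nM, so it stands at the weak end of the numbers in hand (the limit of > 100000 nM in this assay, at which 1 of the 2 values shown sits). Compound 1 `CCOC(=O)c1c(C)[nH]c(=O)c(C#N)c1-c1ccc(C)cc1` gives 15900 nM in this assay. Going by the values given here, the one measured step, an at least 6.2-fold higher number from compound 1 to compound 2 (0.79 log units; beyond the scatter), is the only evidence bearing on the change to compound 3 `CCOC(=O)c1c(C)[nH]c(=O)c(C#N)c1-c1ccc(Br)cc1`, which is bromo in place of cyano on an aromatic carbon. Removing the cyano that came with that loss points toward a lower number, though bromo is not methyl, so only a partial return is expected for compound 3, a step of an at least 2.8-fold lower number from compound 2 to compound 3 (0.45 log units; beyond the scatter). Compound 3 is estimated at 35000 nM (range 12000 nM to 100000 nM).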

Compound 3, half-maximal inhibitory concentration: > 100000 nM
Compound 3 gave a limit, no number; the forecaster's own chance of this, stated with the estimate: 35%; middle value at least 2.8-fold (0.45 log units) from the limit.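

Bromo in place of methyl on the aromatic carbon para to a large group gives an at least 6.2-fold higher number from compound 1 to compound 3 (0.79 log units; beyond the scatter) in this assay, so the loss is not confined to the cyano compound. Of the three groups at this position, only the methyl of compound 1 yields a number. Compound 2 and compound 3 both stand at a limit, not a number, so the step between them cannot be read: the limit of > 100000 nM in this assay, at which 2 of the 3 values shown sit.

As far as these compounds go, what an amine, a methoxy group or a longer alkyl chain would give at this position stays open. From the compounds shown here alone, whether any group here improves on methyl also stays open.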